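Swapping Dimethylamino for Fluoro in a Cytotoxicity Series

The compounds below may be only part of what the source reports. "The series", "measured", "known", "first", "only" and "open" are said of these compounds alone.

Of the compounds shown here, three built on a shared core have been tested in a functional assay on L1210 cells (Mus musculus) for cytotoxicity, with a stated time of 48 h; on this read-out lower numbers stand for stronger inhibition and higher numbers for weaker inhibition. Compound 1 `COc1ccc(/C=C2\CCC/C(=C\c3ccc([N+](=O)[O-])cc3)C2=O)cc1` gives 240000 nM. Compound 2 `CN(C)c1ccc(/C=C2\CCC/C(=C\c3ccccc3[N+](=O)[O-])C2=O)cc1` gives 164000 nM, the second highest of the three numbers. Compound 3 `CN(C)c1ccc(/C=C2\CCC/C(=C\c3cccc([N+](=O)[O-])c3)C2=O)cc1` gives 156000 nM. Going by the values given here, the only single-point step measured, a 1.1-fold lower number from compound 2 to compound 3 (0.02 log units; within the scatter), concerns a different group from the one changed here, and the gap between compound 2 and compound 1 also lies within the scatter, so all three numbers sit close together.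

Compound 4 `O=C1/C(=C/c2ccc(F)cc2)CCC/C1=C\c1ccccc1[N+](=O)[O-]` has not yet been measured. It differs from compound 2 in one place: fluoro in place of dimethylamino on an aromatic carbon. Among the compounds with values here, no measured pair exchanges these two groups, so there is no precedent in this set for how large such a change may be. Against that background, a step of a 1.2-fold higher number from compound 2 to compound 4 (0.09 log units; within the scatter) is expected, not beyond the scatter, with wide uncertainty. Compound 4 is therefore estimated at 200000 nM, ranging from 70000 nM to 600000 nM.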

Compound 4, half-maximal inhibitory concentration: 8400 nM
Compound 4: the middle estimate sits 24-fold (1.38 log units) above what was measured, and the stated range ends above it.
By their numbers in this assay, from the lowest: compound 4; then compounds 3, 2 and 1 (each within the scatter of the next).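

In this assay, the aromatic carbon para to a large group proves sensitive: exchanging dimethylamino for fluoro gives a 20-fold lower number from compound 2 to compound 4 (1.29 log units; beyond the scatter), while the 2-nitrophenyl side stays unchanged. The earlier single-place step, a 1.1-fold lower number from compound 2 to compound 3 (0.02 log units; within the scatter), moved only the nitro group and stayed within the scatter, so it gave no sign that this core could respond so strongly to a single change. Nothing measured here accounts for the size of this step.

From the compounds shown here alone, it remains open whether the lower number comes from the presence of fluoro or from the loss of dimethylamino, a question that a chloro group or a plain hydrogen at the same carbon could help to settle. Going by these compounds, it is also open whether fluoro would give a similar step with the nitro group placed as in compound 3.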